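A few compounds are considered here, and "the series" means these few. Any claim that something is new, unique, unknown or untested is made for them only; others in the source may bear on it.

Measured in an in vitro ADME assay on microsomes from liver (Homo sapiens) for pharmacokinetics, read by LC-MS; on this read-out lower numbers stand for slow clearance and higher numbers for fast clearance:

- compound 1 `Cc1cccc2c1nc(C)n2-c1ccc(C(=O)NC2CC2)s1`: 10 mL/min/kg
- compound 2 `Cc1ccc2nc(C)n(-c3ccc(C(=O)NC4CC4)s3)c2c1`: 10 mL/min/kg
- compound 3 `Cc1nc2ccc(OC(F)(F)F)cc2n1-c1ccc(C(=O)NC2CC2)s1`: 10 mL/min/kg

Compound 1 and compound 2 read the same as compound 3 at the digits shown, so compound 3, at 10 mL/min/kg, stands level with both. The next compound, compound 4 `Cc1nc2ccc(C(F)(F)F)cc2n1-c1ccc(C(=O)NC2CC2)s1`, has not yet been measured. Its difference from compound 3 is trifluoromethyl in place of trifluoromethoxy on an aromatic carbon, in short, trifluoromethyl in place of trifluoromethoxy on an aromatic carbon. Within the data shown here, no measured pair makes this exact exchange. The closest evidence is the step of no change at the digits printed from compound 2 to compound 3 (within the scatter), where trifluoromethoxy took the place of methyl on an aromatic carbon. That is a single step, and it gives no sign of direction. The three measured compounds also show no spread in this assay, so no shift beyond the scatter is expected here. The estimated step is no change at the digits printed from compound 3 to compound 4 (within the scatter), which is expected to stay within the scatter. Compound 4 is expected at 10 mL/min/kg, with an estimated range of 6 mL/min/kg to 17 mL/min/kg.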

Compound 4, clearance: 8 mL/min/kg
Beside the measured number, compound 4's estimate is 1.3-fold (0.10 log units) above it; the range from low to high includes it.
By their numbers in this assay, from the lowest: compounds 4, 1, 2 and 3 (each within the scatter of the next).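

In this assay trifluoromethyl in place of trifluoromethoxy on an aromatic carbon gives a 1.3-fold lower number from compound 3 to compound 4 (0.10 log units; within the scatter) and trifluoromethyl in place of methyl on that same carbon gives a 1.3-fold lower number from compound 2 to compound 4 (0.10 log units; within the scatter) as well. This aromatic carbon has now carried methyl, trifluoromethoxy and trifluoromethyl with every step inside the scatter, and losing the oxygen of trifluoromethoxy, with the one hydrogen-bond acceptor counted for that group, does not carry the clearance beyond it. No measurement shown here explains why the clearance stays so close across these groups.

The compounds shown leave open whether a very different group on this carbon, such as an amine or a carboxylic acid, would move the clearance beyond the scatter. They also leave open how a change elsewhere on the molecule, such as on the amide, would read.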